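Swapping a Pyrazole Sulfonamide for an Aryl Sulfonamide

This account rests on a few compounds, and the source may have more. Where it says the series, first, only, none or still open, it means among the compounds named here.

Within the data shown here, compound 2 `Cn1ccc(S(=O)(=O)Nc2cccc(NC(=O)COc3ccc4c(=O)ccoc4c3)c2)n1` stands at the higher end of the two numbers measured so far. In an assay on isolated protein for inhibition of Rho-associated protein kinase 2 (Homo sapiens), read by scintillation counting, radiometric assay and 33P incorporation, with a stated time of 40 min, in the presence of a further agent that is not named here (a higher number here means a weaker inhibitor, a lower number a stronger inhibitor), compound 2 gives 1350 nM. Compound 1 `CCCc1ccc(C(=O)Nc2cccc(NC(=O)COc3ccc4c(=O)ccoc4c3)c2)cc1` in this assay gives 14 nM, and the step of a 96-fold higher number from compound 1 to compound 2 (1.98 log units; beyond the scatter) is the only measured one; it exchanged an amide-linked propylphenyl group for a sulfonamide-linked methylpyrazole in a single move. Compound 3 `O=C(COc1ccc2c(=O)ccoc2c1)Nc1cccc(NS(=O)(=O)c2ccc(OC(F)(F)F)cc2)c1` keeps the sulfonamide but changes the group on it: 4-(trifluoromethoxy)phenyl in place of 1-methyl-1H-pyrazol-3-yl on a sulfonyl sulfur. Among the measured compounds shown here, the one measured step bears on this only indirectly, since it also altered the linker, yet it shows that a six-membered carbon ring in that region went with a much lower number. Because the step of a 96-fold higher number from compound 1 to compound 2 (1.98 log units; beyond the scatter) was large and is partly reversed here, a lower number beyond the scatter in this assay is expected for compound 3, though not a full return. This expectation amounts to a 9.0-fold lower number from compound 2 to compound 3 (0.95 log units; beyond the scatter). For compound 3 the estimate in this assay is 150 nM, with a range from 30 nM to 700 nM.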

Compound 3, half-maximal inhibitory concentration: 1280 nM
The estimate for compound 3 lay 8.5-fold (0.93 log units) below the measured number; measured number outside the range, above it.
By their numbers in this assay, from the lowest: compound 1; then compounds 3 and 2 (each within the scatter of the next).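

With 4-(trifluoromethoxy)phenyl in place of 1-methyl-1H-pyrazol-3-yl on a sulfonyl sulfur, the step reads a 1.1-fold lower number from compound 2 to compound 3 (0.02 log units; within the scatter), so these two groups cannot be told apart in this assay, although they differ in ring type and the entering group has more heavy atoms. A six-membered aromatic ring of carbon only therefore does not by itself go with a low number: compound 3 carries such a ring and gives 1280 nM, compound 1 carries one too and gives 14 nM, and the earlier step of a 96-fold higher number from compound 1 to compound 2 (1.98 log units; beyond the scatter) can no longer be read as a matter of the ring alone. Nothing available explains why the two sulfonamides read so alike.

The compounds shown leave open whether 4-propylphenyl on the sulfonyl sulfur, or 4-(trifluoromethoxy)phenyl on the amide carbonyl, would separate the effect of the linker from that of the group it carries. They also leave open how a carboxylic acid or an amine on that phenyl ring would read.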